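A few compounds are considered here, and "the series" means these few. Any claim that something is new, unique, unknown or untested is made for them only; others in the source may bear on it.

The series shares a spiro-fused core built around a nitrile and a free amino group, carried into cell-based testing in an ADME assay on L02 cells (Homo sapiens) for antiproliferative activity, read by MTT assay, with a stated time of 48 h; on this read-out higher numbers stand for weaker inhibition and lower numbers for stronger inhibition. Compound 1, `N#CC1=C(N)Oc2c(c3nc4ccccc4nc3c3ccccc23)C12C(=O)N(Cc1cnnn1-c1ccc(S(N)(=O)=O)cc1)c1ccccc12`, carries a sulfonamide-bearing phenyl on its triazole; in this assay compound 1 returns only a limit, > 50000 nM, and no number. Compound 2, `CCc1ccccc1-n1nncc1CN1C(=O)C2(C(C#N)=C(N)Oc3c(N)cc4nc5ccccc5nc4c32)c2ccccc21`, bears a 2-ethylphenyl on the triazole instead, and in this assay compound 2 gives 22900 nM. For the measured compounds named here, compound 2 thus stands as the only value in this assay that is a number; the one other value is a limit, as the limit of > 50000 nM in this assay, at which 1 of the 2 values shown sits, shows, so there is no measured step between the two.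

Compound 3, `COc1ccccc1-n1nncc1CN1C(=O)C2(C(C#N)=C(N)Oc3c(N)cc4nc5ccccc5nc4c32)c2ccccc21`, is the unmeasured partner. It differs from compound 2 by methoxy in place of ethyl on an aromatic carbon, the change sitting on an aromatic carbon of a six-membered aromatic ring of carbon only, ortho to a large group. Going by the values given here, no measured step in this assay guides this change, and the exchange of one two-atom group for another is small, so the expected step from compound 2 to compound 3 is a 1.1-fold higher number from compound 2 to compound 3 (0.04 log units; within the scatter), none beyond the usual scatter. Compound 3 is therefore estimated at 25000 nM, within 10000 nM to 60000 nM.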

Compound 3, half-maximal inhibitory concentration: > 50000 nM
Compound 3: no number, only a limit (the forecaster's own chance of this, stated with the estimate: 30%); middle value at least 2.0-fold (0.30 log units) from the limit.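

Before this pair, the series offered no measured step in this assay, so nothing showed how sensitive this aromatic carbon, ortho to a large group, might be. Methoxy and ethyl hold the same number of heavy atoms, yet the change 2-ethylphenyl to 2-methoxyphenyl gives an at least 2.1-fold higher number from compound 2 to compound 3 (0.33 log units; beyond the scatter), so even an exchange of this size at this position can move the read-out beyond the usual scatter. Compound 3 gives only a limit, > 50000 nM, and not a number, so the step has a lower bound but no known full size, and the same limit recurs in this small set: the limit of > 50000 nM in this assay, at which 2 of the 3 values shown sit.

The compounds shown leave open whether a longer chain such as propyl, a hydroxyl or an amine on this same aromatic carbon would give a number or a limit in this assay. For the compounds shown here, they also leave open whether methoxy in place of ethyl would give a step of similar size with other groups elsewhere on the shared core, since this single pair is the only comparison available.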